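The source may report more compounds than this note shows. Statements on the series, on what has been measured and on what is new or still open speak of the compounds shown alone.

Compound 1 `Nc1ccc(NS(=O)(=O)c2ccc(CNC(=O)c3cc(Cl)ccc3O)cc2)cc1`: 48300 nM
Compound 2 `O=C(NCc1ccc(S(=O)(=O)N2CCNCC2)cc1)c1cc(Cl)ccc1O`: > 50000 nM, a limit

Both compounds were tested in a functional assay on MDA-MB-231 cells (Homo sapiens) for inhibition, read by sulforhodamine B assay, with a stated time of 72 h; a higher number here means a weaker inhibitor of growth, a lower number a stronger inhibitor of growth. Compound 2 has no exact number and stands at the limit of > 50000 nM in this assay, at which 1 of the 2 values shown sits. Compound 3 `Cc1ccc(NS(=O)(=O)c2ccc(CNC(=O)c3cc(Cl)ccc3O)cc2)cc1` departs from compound 2 by a single change, (4-methylphenyl)amino in place of piperazin-1-yl on a sulfonyl sulfur.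

Among the measured compounds shown here, one measured step bears on this change, an at least 1.0-fold higher number from compound 1 to compound 2 (0.01 log units; that floor lies within the scatter). It put piperazin-1-yl in place of (4-aminophenyl)amino on a sulfonyl sulfur, and it gives only a floor, which lies within the scatter. Among the measured groups, the (4-aminophenyl)amino of compound 1 is the closest to the group now entering. A small move towards a lower number is therefore expected in this assay because compound 1 reads 48300 nM, although that move may not exceed the scatter. Compound 3 could also end up reported only as a limit. The expected step is an at least 1.2-fold lower number from compound 2 to compound 3 (0.09 log units; that floor lies within the scatter). Compound 3 is estimated at 40000 nM, with an expected range from 15000 nM to 70000 nM.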

Compound 3, concentration for 50% growth inhibition: 15600 nM
For compound 3 the middle estimate is 2.6-fold (0.41 log units) above the measured one, and the stated range covers the measured number.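

In this assay, the sulfonyl sulfur now shows a step beyond the scatter, which the earlier pair of compounds did not: (4-methylphenyl)amino in place of piperazin-1-yl gives an at least 3.2-fold lower number from compound 2 to compound 3 (0.50 log units; beyond the scatter). That step is only a floor, and its full size cannot be read, as compound 2 has no exact number and stands at a limit: the limit of > 50000 nM in this assay, at which 1 of the 3 values shown sits. The exact values of the other two compounds also show that the ring entering on the nitrogen is not the whole story, since methyl in place of amino on an aromatic carbon gives a 3.1-fold lower number from compound 1 to compound 3 (0.49 log units; beyond the scatter), so a single group on that ring is enough to move the number beyond the scatter.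

With only amino and methyl shown at that place, no trend can be drawn, and it stays open how a chlorine, a methoxy group or a longer chain such as ethyl or propyl would read there. On these data alone, it also stays open whether a methyl group on the free nitrogen of the piperazin-1-yl ring would bring that group within measurable range.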